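The compounds below may be only part of what the source reports. "The series", "measured", "known", "first", "only" and "open" are said of these compounds alone.

Compound 1 `CCOC(=O)c1c(-c2ccc(OC)c(OC)c2)csc1N` in an assay on isolated protein for inhibition of protein kinase C zeta type (Homo sapiens), with stated times of 1 h and 2.5 min, tested at 30 uM (on this read-out lower numbers stand for less inhibition and higher numbers for more inhibition at the one concentration tested (going by the name of the read-out)), gives 100%. Compound 2 `COc1ccc(-c2csc(N)c2C(=O)Oc2ccccc2)cc1OC` in this assay gives 48%.

Of the two measured compounds, compound 2 stands lowest, set apart from compound 1 by a number 52 percentage points lower from compound 1 to compound 2 (beyond the scatter). Compound 3 `COc1ccc(-c2csc(N)c2C(=O)OCc2ccccc2)cc1OC` differs from compound 2 in one place: benzyl in place of phenyl on an oxygen next to a carbonyl group. Among the compounds with values here, the one measured step at this oxygen, a number 52 percentage points lower from compound 1 to compound 2 (beyond the scatter), was large and ran downward. Because compound 1 with ethyl there gave 100% while compound 2 with phenyl gave 48%, compound 3 with benzyl is expected to recover part of that loss, an estimated a number 22 percentage points higher from compound 2 to compound 3 (beyond the scatter). Compound 3 is thus estimated at 70%, in a range from 40% to 100%.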

Compound 3, a percentage reported as inhibition, at one concentration (the size of the read-out at that concentration, not a potency): 100%
Estimate against measurement, compound 3: 30 percentage points below, and the stated range covers the measured number.
By their numbers in this assay, from the lowest: compound 2; then compounds 1 and 3 (each within the scatter of the next).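

Benzyl in place of phenyl on the oxygen next to a carbonyl group gives a number 52 percentage points higher from compound 2 to compound 3 (beyond the scatter) in this assay, so the presence of a six-membered aromatic ring at this oxygen does not by itself bring the lower number of compound 2. Phenyl in place of methyl on the saturated chain carbon gives no change at the digits printed from compound 1 to compound 3 (within the scatter) and leaves compound 1 and compound 3 without any order. No measurement here explains the difference between phenyl and benzyl.

As far as these compounds go, whether a longer chain ending in phenyl, or an amine or carboxylic acid on the chain, would keep this number remains open. From the compounds shown here alone, because this read-out comes from one concentration, the potencies of compound 1 and compound 3 also remain open.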